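Swapping Benzyl for Cyclohexyl on an Inactive Urea

A few compounds are considered here, and "the series" means these few. Any claim that something is new, unique, unknown or untested is made for them only; others in the source may bear on it.

Compound 1 `COc1ccc(/C(=C(/CCN=[N+]=[N-])c2ccccc2)c2ccccc2)cc1`: "not active" (no number reported)
Compound 2 `COc1ccc(/C(=C(/CCNC(=O)Oc2ccccc2)c2ccccc2)c2ccccc2)cc1`: "not active" (no number reported)
Compound 3 `COc1ccc(/C(=C(/CCNC(=O)NCc2ccccc2)c2ccccc2)c2ccccc2)cc1`: > 50000 nM

In a functional assay on MCF7 cells (Homo sapiens) for cytotoxicity, read by MTT assay, with a stated time of 72 h (a lower number here means a stronger inhibitor, a higher number a weaker inhibitor), compound 1 gives "not active" (no number reported). Compound 2 likewise gives "not active" (no number reported) in this assay. For compound 3 the result in this assay is > 50000 nM, which is a limit of the assay rather than a number. Compound 3 therefore sits at the limit of > 50000 nM in this assay, at which 1 of the 3 values shown sits. For the measured compounds named here, no two measured compounds differ in one place, so no measured step can be drawn. Compound 4 `COc1ccc(/C(=C(/CCNC(=O)NC2CCCCC2)c2ccccc2)c2ccccc2)cc1` changes compound 3 by cyclohexyl in place of benzyl on an amide-type nitrogen. Since every measured compound is inactive or at the limit, the step that the limit leaves unreadable from compound 3 to compound 4 is expected to be none beyond the scatter. Compound 4 is estimated at 80000 nM, within 30000 nM to 300000 nM, most likely again reported only as a limit.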

Compound 4, half-maximal inhibitory concentration: 37200 nM
Estimate against measurement, compound 4: 2.2-fold (0.33 log units) above; measured number inside the range.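

In this assay compound 4 gives 37200 nM, the first actual number among the compounds shown, so this nitrogen can carry a group that gives a readable value. Compound 3 stands at a limit of the assay, not at a number: the limit of > 50000 nM in this assay, at which 1 of the 4 values shown sits. The change from benzyl to cyclohexyl gives an at least 1.3-fold lower number from compound 3 to compound 4 (0.12 log units; that floor lies within the scatter), so no real gain can be claimed for it.

From the compounds shown here alone, how close compound 3 truly lies to compound 4 remains open. So does the effect of a cyclopentyl group, a longer chain or an amine in this place.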